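A few compounds are considered here, and "the series" means these few. Any claim that something is new, unique, unknown or untested is made for them only; others in the source may bear on it.

Compound 1 `NNC(=O)Cn1nc(N)c2c(C(F)(F)F)cc(-c3ccccc3)nc21` gave 53600 nM in a functional assay on A549 cells (Homo sapiens) for cytotoxicity, read by MTT assay, with a stated time of 24 h; a higher number here means a weaker inhibitor, a lower number a stronger inhibitor. Compound 2 `Nc1nn(CC(=O)NC2CCCCC2)c2nc(-c3ccccc3)cc(C(F)(F)F)c12` gave 2300 nM in this assay.

For the measured compounds named here, compound 2 holds the lower of the two numbers, set apart from compound 1 by the single measured step, a 23-fold lower number from compound 1 to compound 2 (1.37 log units; beyond the scatter). Compound 3 `Nc1nn(CC(=O)N2CCOCC2)c2nc(-c3ccccc3)cc(C(F)(F)F)c12` differs from compound 2 by morpholin-4-yl in place of cyclohexylamino on a carbonyl carbon. That one step bears on this change only loosely: it built the ring on the amide-type nitrogen, whereas here a ring remains but the hydrogen-bond donor is lost. Going by the values given here, no measured step tests that. The author expects a modest rise in the number, a 2.6-fold higher number from compound 2 to compound 3 (0.42 log units; beyond the scatter), for compound 3, estimated at 6000 nM with a range of 2000 nM to 20000 nM.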

Compound 3, half-maximal inhibitory concentration: 5400 nM
Estimate against measurement, compound 3: 1.1-fold (0.05 log units) above; low and high end bracket the measured number.
By their numbers in this assay, from the lowest: compound 2; then compound 3; then compound 1.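

Morpholin-4-yl on the carbonyl carbon keeps most of the gain over the amino-bearing hydrazide (a 9.9-fold lower number from compound 1 to compound 3 (1.00 log units; beyond the scatter)), even though the amide hydrogen is gone and the ring now holds a second hetero atom. The price in this assay for leaving cyclohexylamino is real but modest (a 2.3-fold higher number from compound 2 to compound 3 (0.37 log units; beyond the scatter)). Nothing given here explains either step.

The change from compound 2 to compound 3 removes a donor and adds a ring oxygen together, so the two stay unseparated. A piperidin-1-yl group on the same carbonyl carbon would pull them apart, and an open-chain diethylamino group would test whether any ring is needed.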